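Ester chain shift on compound 3: working notes

The source may report more compounds than this note shows. Statements on the series, on what has been measured and on what is new or still open speak of the compounds shown alone.

Measured in a functional assay on A-427 cells (Homo sapiens) for cytotoxicity, read by colorimetric assay and MTT assay; a lower number here means a stronger inhibitor, a higher number a weaker inhibitor:
- compound 1 `COc1cccc2cc(-c3ccccc3)c(O)nc12` gives 10000 nM
- compound 2 `COc1ccc2cc(-c3ccccc3)c(O)nc2c1` gives 10000 nM
- compound 3 `CCOC(=O)Cn1c(=O)c(-c2ccc(OC)cc2)cc2c(OC)cc(OC)cc21` gives 10000 nM

All three compounds carry the same value at the digits reported, so none separates from the others in this assay and compound 3 stands level with compound 1 and compound 2. Going by the values given here, the set contains no step between measured compounds that differ in one place, so nothing here shows how a single change acts on this read-out.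

The next compound is compound 4 `COC(=O)CCn1c(=O)c(-c2ccc(OC)cc2)cc2c(OC)cc(OC)cc21`, an isomer of compound 3 with the same atoms joined differently. The change is (methoxycarbonyl)methyl in place of ethoxycarbonyl on a saturated chain carbon bound to an aromatic nitrogen and the same difference, cut one bond further out, reads (ethoxycarbonyl)methyl to 2-(methoxycarbonyl)ethyl.

Among the compounds with values here, the only guide is the flat picture, with compound 3 at 10000 nM as the direct reference. The estimated no change at the digits printed from compound 3 to compound 4 (within the scatter) is expected to stay within the usual scatter, with no direction favoured. For compound 4 the expected value is 10000 nM with an estimated range from 5000 nM to 18000 nM in this read-out.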

Compound 4, half-maximal inhibitory concentration: 10000 nM
Compound 4: the middle estimate sits on the measured number at the digits printed; the range from low to high includes it.
By their numbers in this assay, from the lowest: compounds 1, 2, 3 and 4 (each within the scatter of the next).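

In this assay the series now has its first step between compounds that differ in one place, and that step reads no change at the digits printed from compound 3 to compound 4 (within the scatter). The change is (methoxycarbonyl)methyl in place of ethoxycarbonyl on a saturated chain carbon bound to an aromatic nitrogen, so for this pair, with the same atoms joined differently, the shift of the ester along the chain does not separate the two compounds, a comparison that compounds 1 and 2 could not offer; this single step supports no rule beyond compounds 3 and 4. No measurement shown here bears on the reason for this result.

On these data alone, whether a carboxylic acid, an amide or an amine in place of the ester, or a longer chain carrying it, would separate from compound 3 remains open. Also open is whether any change at this position can move the read-out away from the level shared by all four compounds, since the pair shown gives no direction.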